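Nitrogen-substituent variation in a pyridyl-bearing series

This account rests on a few compounds, and the source may have more. Where it says the series, first, only, none or still open, it means among the compounds named here.

Compound 1 `Cn1nc(-c2cccnc2)c2ccccc2c1=O` gives 63% in an assay on isolated protein (Oryctolagus cuniculus) with Thromboxane-A synthase (Homo sapiens) as the target, tested at 1 uM; a higher number here means more inhibition at the concentration tested (going by the name of the read-out), a lower number less inhibition. Compound 2 `CC(C)=CCn1nc(-c2cccnc2)c2ccccc2c1=O` gives 94%, and compound 3 `CCOC(=O)Cn1nc(-c2cccnc2)c2ccccc2c1=O` gives 28%, the lowest of the three numbers. Compound 4 `NCCn1nc(-c2cccnc2)c2ccccc2c1=O` is not yet measured. The change is aminomethyl in place of ethoxycarbonyl on a saturated chain carbon bound to an aromatic nitrogen. Of the measured steps, a number 35 percentage points lower from compound 1 to compound 3 (beyond the scatter) and a number 66 percentage points lower from compound 2 to compound 3 (beyond the scatter) bear on it, both large and both showing that ethoxycarbonyl on this carbon sits lowest; a number 31 percentage points higher from compound 1 to compound 2 (beyond the scatter) shows how much another substituent on this carbon can add. Removing ethoxycarbonyl is therefore expected to raise the read-out, with the size of the aminomethyl effect open, so a step of a number 27 percentage points higher from compound 3 to compound 4 (beyond the scatter) is expected. Compound 4 is estimated at 55%, between 25% and 85%.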

Compound 4, a percentage reported as inhibition, at one concentration (the size of the read-out at that concentration, not a potency): 29%
Compound 4: middle estimate off by 26 percentage points, on the high side; the range from low to high includes it.
By their numbers in this assay, from the lowest: compounds 3 and 4 (each within the scatter of the next); then compound 1; then compound 2.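

On the saturated chain carbon bound to an aromatic nitrogen, aminomethyl and ethoxycarbonyl do not separate, with a number 1 percentage points higher from compound 3 to compound 4 (within the scatter). Two quite different groups therefore both fall short of the methyl compound, with a number 34 percentage points lower from compound 1 to compound 4 (beyond the scatter), and the high read-out with 2-methylprop-1-en-1-yl remains well apart, with a number 65 percentage points lower from compound 2 to compound 4 (beyond the scatter). No evidence at hand accounts for this.

From the compounds shown here alone, whether a carboxylic acid in place of ethoxycarbonyl, a longer chain carrying the amine, or a saturated alkyl chain in place of 2-methylprop-1-en-1-yl would move the read-out stays open.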